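A few compounds are considered here, and "the series" means these few. Any claim that something is new, unique, unknown or untested is made for them only; others in the source may bear on it.

Working notes on the series. Among the measured compounds shown here, in a functional assay on A-375 cells (Homo sapiens) for antiproliferative activity (a higher number here means a weaker inhibitor, a lower number a stronger inhibitor), compound 1 `O=C(Nc1ccc(-c2cscn2)cc1)C1CCCN(Cc2ccc(F)c(F)c2)C1` gives 880 nM, the lowest of the numeric values so far. Compound 3 `O=C(Nc1ccc(-c2cscn2)cc1)[C@@H]1CCCN(Cc2ccc(F)c(F)c2)C1` gives 6000 nM. The measured step is a 6.8-fold higher number from compound 1 to compound 3 (0.83 log units; beyond the scatter), and it comes with the fact that one of compounds 1 and 3 is drawn with a defined configuration and the other without, at the place where they differ. Compound 2 `O=C(Nc1ccc(-c2cscn2)cc1)C1CCN(Cc2ccc(F)c(F)c2)CC1` reaches only a limit of the assay, > 20000 nM.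

Compound 4 `O=C(Nc1ccc(-c2cscn2)cc1)C1CCCN(Cc2cccc(F)c2F)C1` is not yet measured. The change is 2,3-difluorophenyl in place of 3,4-difluorophenyl on a saturated chain carbon bound to an amine nitrogen in a ring, with 2,3-difluorophenyl in place of 3,4-difluorophenyl on a saturated chain carbon bound to an amine nitrogen in a ring. For the measured compounds named here, no measured step alters the fluorine pattern, so a 6.8-fold higher number from compound 1 to compound 3 (0.83 log units; beyond the scatter) serves only as a rough gauge of how far a single change can move this assay. A modest step toward a higher number is expected, though the direction is weakly supported and rests only on compound 1 holding the lowest number at 880 nM. The estimated step is a 1.7-fold higher number from compound 1 to compound 4 (0.23 log units; within the scatter). For compound 4 the estimate is 1500 nM, with an expected range of 400 nM to 6000 nM.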

Compound 4, half-maximal inhibitory concentration: 1480 nM
Estimate against measurement, compound 4: 1.0-fold (0.01 log units) above; measured number inside the range.
By their numbers in this assay, from the lowest: compounds 1 and 4 (each within the scatter of the next); then compound 3. At a limit, above all of these: compound 2.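

In this assay, 2,3-difluorophenyl in place of 3,4-difluorophenyl on a saturated chain carbon bound to an amine nitrogen in a ring gives a 1.7-fold higher number from compound 1 to compound 4 (0.23 log units; within the scatter). This is the only step at this position among the compounds shown, and it shows that these two fluorine patterns cannot be told apart in this read-out, whereas the stereo-drawing step, a 6.8-fold higher number from compound 1 to compound 3 (0.83 log units; beyond the scatter), lies beyond the scatter. Nothing at hand bears on the cause of the fluorine step.

Still open, going by these compounds, is whether this position keeps its number with an unsubstituted phenyl, a single fluorine, or a larger group such as methoxy or trifluoromethyl. Also open, on these data alone, is how the 2,3-difluorobenzyl compound would read with a defined configuration at the saturated ring carbon.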